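The source may hold more compounds than are shown below. What is called first, only, known or untested is meant among the compounds shown, and "the series" means these compounds.

Of the compounds shown here, three built on one shared core have been measured in a physicochemical assay for lipophilicity, measured as chromatographic lipophilicity, at pH 7.4; on this read-out lower numbers stand for lower lipophilicity and higher numbers for higher lipophilicity. Compound 1 `COc1cc(-c2nnc3n2CCCC3(c2ccc(Cl)c(Cl)c2)C(C)(C)O)ccc1-c1cnc(C)o1` gives 3.7, and compound 2 `COc1cc(-c2nnc3n2CCCC3(Cc2ccc(F)c(F)c2)C(C)(C)O)ccc1-c1cnc(C)o1` gives 3. For the measured compounds named here, the only measured step among them is a number 0.70 log units lower from compound 1 to compound 2 (beyond the scatter). Compound 3 `COc1cc(-c2nnc3n2CCC[C@@]3(Oc2cc(F)c(F)c(F)c2)C(C)(C)O)ccc1-c1cnc(C)o1` gives 3.2. This number lies within the usual scatter of the value of compound 2 and beyond the scatter under the value of compound 1.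

Compound 4 `COc1cc(-c2nnc3n2CCC[C@]3(Oc2cc(F)c(F)c(F)c2)C(C)(C)O)ccc1-c1cnc(C)o1` has not yet been measured. Set against compound 3, the change is the two compounds have the same atoms and bonds and differ only in configuration as drawn: 1 of 1 stereo elements differ; a stereocentre at a saturated ring carbon is drawn S in compound 3 and R in compound 4: the two compounds have the same atoms and bonds, and a stereocentre at a saturated ring carbon is drawn S in compound 3 and R in compound 4.

Going by the values given here, the one measured step offers little guidance. In a number 0.70 log units lower from compound 1 to compound 2 (beyond the scatter), one group is exchanged for another, whereas here nothing leaves and nothing enters. Among the compounds with values here, no pair differing only in configuration has been measured, so the data give no direct size for such a change. The expectation therefore rests on compound 3 at 3.2, and no step beyond the scatter is foreseen in this assay. The estimated change is no change at the digits printed from compound 3 to compound 4 (within the scatter). Compound 4 is expected at 3.2, within an estimated range from 2.9 to 3.5.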

Compound 4, distribution coefficient: 3.2
Estimate against measurement, compound 4: no gap at the digits printed; the range from low to high includes it.
By their numbers in this assay, from the lowest: compounds 2, 3 and 4 (each within the scatter of the next); then compound 1.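

In this assay, the study now has a pair that differs only in configuration, and the result is no change at the digits printed from compound 3 to compound 4 (within the scatter). This gives a first size for such a change at this saturated ring carbon, which the earlier step could not give, since that step exchanged one group for another. The comparison is a clean one, with the stereocentre as the only variable, and the flat result has to be read against a single fact: the fact that compounds 3 and 4 differ only in the configuration as drawn

As far as these compounds go, the finding rests on one pair carrying one group on this carbon, so it cannot be extended to the shared core in general, and whether two mirror-drawn forms would also stay together with an amine or a carboxylic acid at the same position remains open. From the compounds shown here alone, how the two configurations compare in any other kind of assay also remains open, since a match on this read-out says nothing about behaviour elsewhere.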